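The source may hold more compounds than are shown below. What is called first, only, known or untested is meant among the compounds shown, and "the series" means these compounds.

Compound 1 `N#Cc1ccccc1-c1cnc(C(=O)CCCCCCc2ccccc2)o1`, compound 2 `COC(=O)c1ccc(-c2cnc(C(=O)CCCCCCc3ccccc3)o2)cc1` and compound 3 `O=C(O)c1ccc(-c2cnc(C(=O)CCCCCCc3ccccc3)o2)cc1` share one core and differ only in the aryl group attached to it. In an assay (Rattus norvegicus) for inhibition of Fatty-acid amide hydrolase 1 (Homo sapiens) (on this read-out lower numbers stand for stronger inhibition and higher numbers for weaker inhibition), compound 1 gives 130 nM, compound 2 gives 40 nM and compound 3 gives 60 nM, so compound 1 has the highest number of the three and therefore the weakest inhibition. Compound 4 `O=C(CCCCCCc1ccccc1)c1ncc(-c2ccc(O)cc2)o1` has not yet been measured. Relative to compound 1 it carries 4-hydroxyphenyl in place of 2-cyanophenyl on an aromatic carbon. The measured step that bears on this is a 2.2-fold lower number from compound 1 to compound 3 (0.34 log units; beyond the scatter), where another aryl group took the place of 2-cyanophenyl, while a 1.5-fold higher number from compound 2 to compound 3 (0.18 log units; within the scatter) shows little change between ester and acid. A modest move toward stronger inhibition is therefore expected, a 2.2-fold lower number from compound 1 to compound 4 (0.34 log units; beyond the scatter). Compound 4 is estimated at 60 nM, within a range from 25 nM to 150 nM.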

Compound 4, inhibition constant: 140 nM
Beside the measured number, compound 4's estimate is 2.3-fold (0.37 log units) below it; the range from low to high includes it.
By their numbers in this assay, from the lowest: compounds 2 and 3 (each within the scatter of the next); then compounds 1 and 4 (each within the scatter of the next).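

Exchanging 2-cyanophenyl for 4-hydroxyphenyl on this aromatic carbon gives a 1.1-fold higher number from compound 1 to compound 4 (0.03 log units; within the scatter), so the two groups cannot be told apart here. Hydroxy in place of carboxy gives a 2.3-fold higher number from compound 3 to compound 4 (0.37 log units; beyond the scatter), and hydroxy in place of methoxycarbonyl gives a 3.5-fold higher number from compound 2 to compound 4 (0.54 log units; beyond the scatter), so the stronger inhibition of compound 2 and compound 3 does not extend to compound 4 and the group on the phenyl ring matters. Nothing measured here explains this difference. Open, as far as these compounds go, is where an amine or a methoxy group in place of that hydroxy would fall, and whether an amide would behave like the ester and the acid.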